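The source may report more compounds than this note shows. Statements on the series, on what has been measured and on what is new or still open speak of the compounds shown alone.

Three close relatives of one amide have been tested for their power to kill a leukaemia cell line. Compound 1 `O=C(Nc1ccc(OC(F)(F)F)cc1)c1cc(F)ccc1O`, compound 2 `O=C(Nc1ccc(C(F)(F)F)cc1)c1cc(F)ccc1O` and compound 3 `O=C(Nc1ccc(OC(F)(F)F)c(Cl)c1)c1cc(Cl)ccc1O` were each measured in a functional assay on NALM-6 cells (Homo sapiens) for cytotoxicity, read by luminescence and CellTiter-Glo, with a stated time of 3 days; a higher number here means a weaker inhibitor, a lower number a stronger inhibitor. In this assay compound 1 gives 1210 nM, compound 2 gives 2090 nM and compound 3 gives 1050 nM. All three numbers lie close together, so none of the three can be called stronger or weaker than another.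

Compound 1 and compound 2 differ in a single place: trifluoromethyl in place of trifluoromethoxy on an aromatic carbon. This change produced a 1.7-fold higher number from compound 1 to compound 2 (0.24 log units; within the scatter). The difference between the core of compound 1 and the core of compound 3 is not broken down here.

Compound 4 `O=C(Nc1ccc(C(F)(F)F)c(Cl)c1)c1cc(Cl)ccc1O` has not yet been measured. It is made from compound 3 by the change (trifluoromethyl in place of trifluoromethoxy on an aromatic carbon). The surroundings are not identical to those in the first pair: in compound 3 the group that leaves sits ortho to a chloro group, whereas in compound 1 it does not, so this is the same kind of change rather than the same change.

Because the same kind of change gave a 1.7-fold higher number from compound 1 to compound 2 (0.24 log units; within the scatter), compound 4 is expected to show a 1.7-fold higher number from compound 3 to compound 4 (0.23 log units; within the scatter) in this assay. In this assay compound 4 is therefore estimated to give 1800 nM, most likely somewhere between 900 nM and 3600 nM.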

Compound 4, half-maximal inhibitory concentration: 1220 nM
For compound 4 the middle estimate is 1.5-fold (0.17 log units) above the measured one, within the range that was stated.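

In this assay, putting trifluoromethyl in place of trifluoromethoxy on the core of compound 3 gave a 1.2-fold higher number from compound 3 to compound 4 (0.07 log units; within the scatter), so on this core the swap leaves no change that can be told apart from ordinary repeat-to-repeat variation. Set beside the earlier case, the swap behaves alike on both cores as far as these numbers can tell, even though on the core of compound 3 the changing group sits ortho to a chloro group: the same change on two cores in this assay, a 1.7-fold higher number (0.24 log units; within the scatter) from compound 1 to compound 2 and a 1.2-fold higher number (0.07 log units; within the scatter) from compound 3 to compound 4, 1.5-fold (0.17 log units) apart, within the scatter of two such steps This shows that, between these two cores, the result of the swap carried over in the simple sense that neither step stands out from the scatter, but it does not show that the swap has no effect at all, since a small real effect could hide inside that scatter, and two pairs say nothing about any other core in the series.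

The compounds shown leave open what would happen if a clearly different group, such as an amine or a carboxylic acid, stood at that same place on the aromatic ring. They also leave open whether a longer chain there would move the number beyond the scatter in this assay, as all four compounds carry only trifluoromethyl or trifluoromethoxy at that place.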